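Trimming an Aryl Sulfonamide Down to a Methyl Group

A few compounds are considered here, and "the series" means these few. Any claim that something is new, unique, unknown or untested is made for them only; others in the source may bear on it.

Compound 1 `Nc1cc(NS(=O)(=O)c2ccc(F)cc2F)cc(-c2cnc3[nH]cc(-c4ccncc4)c3c2)c1` and compound 2 `COc1cccc(-c2cnc3[nH]cc(-c4ccncc4)c3c2)c1` share one core and differ in what hangs from it. In an assay on isolated protein for inhibition of high affinity nerve growth factor receptor (Homo sapiens), read by 33P incorporation (on this read-out higher numbers stand for weaker inhibition and lower numbers for stronger inhibition), compound 1 gives 2.97 nM, while compound 2 gives 22.7 nM. Within the data shown here, of the two numbers known, compound 1 holds the lower one, and its gap to compound 2 lies beyond the scatter of repeated measurements, so compound 1 is the stronger inhibitor of this pair.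

Compound 3 `CS(=O)(=O)Nc1cc(N)cc(-c2cnc3[nH]cc(-c4ccncc4)c3c2)c1` has not yet been measured. It keeps everything else of compound 1 and changes only the sulfonamide: methyl in place of 2,4-difluorophenyl on a sulfonyl sulfur. A ring-bearing group is exchanged for the smallest carbon group, so a sizeable part of compound 1 is simply cut away. Among the measured compounds shown here, no measured pair shows this exact change, so the size of the step can only be estimated. The expectation is that some potency is lost: the expected step is a 4.0-fold higher number from compound 1 to compound 3 (0.61 log units; beyond the scatter), a weakening beyond the scatter. Compound 3 is therefore expected to give about 12 nM in this assay, with a likely range from 3.5 nM to 45 nM.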

Compound 3, half-maximal inhibitory concentration: 33.8 nM
Beside the measured number, compound 3's estimate is 2.8-fold (0.45 log units) below it, and the stated range covers the measured number.
By their numbers in this assay, from the lowest: compound 1; then compounds 2 and 3 (each within the scatter of the next).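

Replacing 2,4-difluorophenyl with methyl on the sulfonyl sulfur gives an 11-fold higher number from compound 1 to compound 3 (1.06 log units; beyond the scatter) in this assay, so the group on this sulfur has a strong influence on the measured potency. Compound 1 and compound 2 differ in more than one place and could not show this, whereas compound 1 and compound 3 differ only in this group, so the loss can be assigned to this one exchange. No measurement here explains why the exchange weakens inhibition.

The compounds shown do not separate the contribution of the six-membered aromatic ring from that of its two fluorine atoms, a question that an unsubstituted phenyl group on the same sulfonyl sulfur could help answer. They also leave open how potency changes between the two extremes of methyl and 2,4-difluorophenyl, where an ethyl, propyl or cyclopropyl group would show whether a smaller carbon group can recover part of the loss.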